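Amide replacements on a prenylated quinolinone core: thiophene for methoxyphenyl

The compounds below may be only part of what the source reports. "The series", "measured", "known", "first", "only" and "open" are said of these compounds alone.

Compound 1 `CC(C)=CCC/C(C)=C/COc1cc(=O)n(CCCO)c2c1CC(CC=C(C)C)C(C)(C)C2` gives 18.4% in a functional assay on PANC-1 cells (Homo sapiens) for inhibition, read by MTT assay, with a stated time of 24 h, tested at 10 uM; a higher number here means more inhibition at the concentration tested (going by the name of the read-out), a lower number less inhibition; compound 2 `CC(C)=CCC1Cc2c(OCCCNS(=O)(=O)c3ccc([N+](=O)[O-])cc3)cc(=O)n(CCCO)c2CC1(C)C` gives 17.3%; compound 3 `COc1ccc(C(=O)NCCCOc2cc(=O)n(CCCO)c3c2CC(CC=C(C)C)C(C)(C)C3)cc1` gives 2.5%.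

Compound 3 stands lowest of these three numbers, with compound 2 nearest and compound 1 furthest, both gaps beyond the scatter. Going by the values given here, the only single-place step, a number 14.8 percentage points lower from compound 2 to compound 3 (beyond the scatter), changed the group on the amine nitrogen; it bears on the amide region but not on the aryl group itself. Compound 4 `CC(C)=CCC1Cc2c(OCCCNC(=O)c3cccs3)cc(=O)n(CCCO)c2CC1(C)C` differs from compound 3 as follows: thiophen-2-yl in place of 4-methoxyphenyl on a carbonyl carbon. Among the compounds with values here, no measured step addresses this aryl swap, so no direction is supported beyond the scatter, and the step of a number 4.5 percentage points higher from compound 3 to compound 4 (within the scatter) is expected to stay small. Compound 4 is estimated at 7%, within -4% to 20%.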

Compound 4, a percentage reported as inhibition, at one concentration (the size of the read-out at that concentration, not a potency): 5.6%
Compound 4: the middle estimate sits 1.4 percentage points above what was measured, within the range that was stated.
By their numbers in this assay, from the lowest: compounds 3 and 4 (each within the scatter of the next); then compounds 2 and 1 (each within the scatter of the next).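

In this assay, the aryl swap on the carbonyl carbon stays within the scatter (a number 3.1 percentage points higher from compound 3 to compound 4 (within the scatter)), so these compounds do not separate thiophen-2-yl from 4-methoxyphenyl at this place. With thiophen-2-yl, the amide again lies beyond the scatter from the (4-nitrophenyl)sulfonyl compound (a number 11.7 percentage points lower from compound 2 to compound 4 (beyond the scatter)) and from the 2,6-dimethylhepta-1,5-dien-1-yl compound (a number 12.8 percentage points lower from compound 1 to compound 4 (beyond the scatter)). Nothing available explains these steps.

Still open, going by these compounds, is whether a pyridin-2-yl or a simple methyl on the carbonyl carbon would give a number beyond the scatter from these two amides. On these data alone, whether a 4-nitrophenyl group on that carbonyl would recover the number of compound 2 also remains unknown.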